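Azido series: replacing the aryl group of compound 2

The compounds below may be only part of what the source reports. "The series", "measured", "known", "first", "only" and "open" are said of these compounds alone.

Values in a functional assay on HCT-116 cells (Homo sapiens) for cytotoxicity, read by MTT assay, with a stated time of 72 h; a lower number here means a stronger inhibitor, a higher number a weaker inhibitor:
- compound 1 `COc1cc2nc(Cc3ccc(Cl)cc3)[nH]c(=O)c2cc1OC` gives > 10000 nM, which is a limit of this assay, not a number.
- compound 2 `COc1cc2nc(-c3ccccc3Cl)nc(N=[N+]=[N-])c2cc1OC` gives > 10000 nM, again only a limit of this assay.
- compound 3 `COc1ccc(-c2nc(N=[N+]=[N-])c3cc(OC)c(OC)cc3n2)cc1` gives 7000 nM.

Compound 2 therefore stands at the limit of this assay, with no number of its own; the same holds for compound 1, and only compound 3 carries a measured value (the limit of > 10000 nM in this assay, at which 2 of the 3 values shown sit).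

Compound 4 `COc1cc2nc(-c3ccc(C)cc3)nc(N=[N+]=[N-])c2cc1OC` is the not yet measured analogue of compound 2 with a (4-methylphenyl in place of 2-chlorophenyl on an aromatic carbon).

Among the compounds with values here, the only measured step that bears on this change is the one from compound 2 to compound 3, where a different para-substituted phenyl replaces the same 2-chlorophenyl: an at least 1.4-fold lower number from compound 2 to compound 3 (0.15 log units; that floor lies within the scatter). That step is small and, given that compound 2 is only a limit, its true size is not known. The change to compound 4 is of the same kind, so no step beyond the scatter is expected in this assay from compound 2 to compound 4, and a value near the limit of this assay, or again a limit, is the likely outcome.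

Compound 4 is thus expected at 8000 nM (range 3000 nM to 25000 nM), which as a step from compound 2 means an at least 1.2-fold lower number from compound 2 to compound 4 (0.09 log units; that floor lies within the scatter).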

Compound 4, half-maximal inhibitory concentration: 9000 nM
For compound 4 the middle estimate is 1.1-fold (0.05 log units) below the measured one, within the range that was stated.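

In this assay, within the data shown here, the first step at this position that joins two measured numbers is a 1.3-fold higher number from compound 3 to compound 4 (0.11 log units; within the scatter), so 4-methylphenyl and 4-methoxyphenyl cannot be told apart here. Against compound 2 there is only a floor, an at least 1.1-fold lower number from compound 2 to compound 4 (0.04 log units; that floor lies within the scatter), which leaves two 4-substituted phenyl groups with measured values beside a 2-chlorophenyl group with none. The true size of that step stays unknown because compound 2 has no number of its own and stands at a limit of the assay: the limit of > 10000 nM in this assay, at which 2 of the 4 values shown sit.

The compounds shown do not separate the removal of the 2-chloro substituent from the arrival of a substituent at the 4-position of the phenyl ring, a question that 4-chlorophenyl and plain phenyl at the same place would address. Among these compounds, also open is whether a 4-aminophenyl or 4-carboxyphenyl group would give a step beyond the scatter from compound 4, since methyl and methoxy are the only groups compared there so far.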